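The compounds below may be only part of what the source reports. "The series", "measured", "known", "first", "only" and "open" are said of these compounds alone.

Values so far in an ADME assay on liver (Mesocricetus auratus) for metabolic stability, using microsomes; on this read-out higher numbers stand for fast clearance and lower numbers for slow clearance:

Compound 1 (`COc1ccc(C(=O)Nc2[nH]nc(-c3ccccn3)c2C2CC2)cc1`): > 100 mL.min-1.g-1 (a limit of the assay, not a number)
Compound 2 (`O=C(Nc1cc(-c2ccccn2)n[nH]1)N1CCC(c2cccc(F)c2)CC1`): 207 mL.min-1.g-1

Among the measured compounds shown here, compound 2 holds the only true number so far. The entry for compound 1 is a limit only.

The next step goes from compound 2 to compound 3 (`N#Cc1ccc(OC2CCN(C(=O)Nc3cc(-c4ccccn4)n[nH]3)CC2)cc1`) and puts 4-cyanophenoxy in place of 3-fluorophenyl on a saturated ring carbon three ring bonds from the ring nitrogen. For the measured compounds named here, no measured pair isolates a change of this kind, so the expectation in this assay is a modest fall, perhaps none beyond the scatter. With compound 2 at 207 mL.min-1.g-1 as the only anchor, fast clearance is expected to persist. The expected change is a 1.6-fold lower number from compound 2 to compound 3 (0.20 log units; within the scatter) and it remains tentative. For compound 3 the estimate is 130 mL.min-1.g-1 with an expected range from 50 mL.min-1.g-1 to 320 mL.min-1.g-1 in this series.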

Compound 3, intrinsic clearance in microsomes: 30.8 mL.min-1.g-1
The estimate for compound 3 lay 4.2-fold (0.63 log units) above the measured number; measured number below the stated range.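

In this assay, the saturated ring carbon three ring bonds from the ring nitrogen proves sensitive to the group it carries: 4-cyanophenoxy in place of 3-fluorophenyl gives a 6.7-fold lower number from compound 2 to compound 3 (0.83 log units; beyond the scatter). Among the compounds shown here, this is the first readable step, and it shows that the read-out is not set by the shared core alone, since this one change moves it beyond the scatter. Compound 1 differs in more than one place and stays outside the comparison, and its entry is only a limit: the limit of > 100 mL.min-1.g-1 in this assay, at which 1 of the 3 values shown sits.

As far as these compounds go, it remains open which part of 4-cyanophenoxy carries the step, the oxygen or the nitrile. Also open, from the compounds shown here alone, is how an amine or a carboxylic acid on this saturated ring carbon would read in this assay.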